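The source may hold more compounds than are shown below. What is called first, only, known or untested is meant among the compounds shown, and "the series" means these compounds.

Measured compounds:
compound 1 `O=C1O[C@@H](CN2CCCCC2)CN1c1ccc(-n2cc(-c3ccccn3)cn2)c(F)c1` — in a physicochemical assay for lipophilicity, read by HPLC, measured as octanol-water partition (a lower number here means a more polar compound, a higher number a more lipophilic compound), compound 1 gives 3.1
compound 2 `CC(=O)OC[C@H]1CN(c2ccc(-n3cc(-c4ccccn4)cn3)c(F)c2)C(=O)O1` — in this assay compound 2 gives 2.09

Going by the values given here, compound 2 stands lowest of the two numbers in this assay; its nearest neighbour is compound 1, and the only measured step, a number 1.01 log units lower from compound 1 to compound 2 (beyond the scatter), lies beyond the scatter. Compound 3 `O=CNC[C@H]1CN(c2ccc(-n3cc(-c4ccccn4)cn3)c(F)c2)C(=O)O1` has not yet been measured. Its change from compound 2 is formylamino in place of acetoxy on a saturated chain carbon bound to a saturated ring carbon. Among the compounds with values here, no measured step covers this exact exchange; the one step available, a number 1.01 log units lower from compound 1 to compound 2 (beyond the scatter), concerns a different group at the same place and shows only that this position can move the number substantially. The group that leaves holds two hydrogen-bond acceptors and no donor, the one that enters holds one donor and one acceptor, so a downward step beyond the scatter is expected in this assay, estimated as a number 0.89 log units lower from compound 2 to compound 3 (beyond the scatter). For compound 3 the estimate in this assay is 1.2, ranging from 0.7 to 1.7.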

Compound 3, partition coefficient: 1.19
Estimate against measurement, compound 3: 0.01 log units above; measured number inside the range.
By their numbers in this assay, from the lowest: compound 3; then compound 2; then compound 1.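

In this assay formylamino in place of acetoxy gives a number 0.90 log units lower from compound 2 to compound 3 (beyond the scatter) on a saturated chain carbon bound to a saturated ring carbon, so this position moves the number even between two groups with no net charge and one double bond outside aromatic rings each. Formylamino in place of piperidin-1-yl gives a number 1.91 log units lower from compound 1 to compound 3 (beyond the scatter) and leaves compound 3 with the lowest of the three numbers. Nothing measured here accounts for the size of these steps.

The compounds shown do not separate the hydrogen-bond donor that enters with formylamino from the other differences between the two groups. As far as these compounds go, how an acetylamino group, a primary amine or a carboxylic acid at this place would read in this assay also stays open.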